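This account rests on a few compounds, and the source may have more. Where it says the series, first, only, none or still open, it means among the compounds named here.

Measured compounds:
- compound 1 `CCCc1nc(-c2ccccc2)c(CNCCN2CCN(c3ccc(C)cc3)CC2)o1`: 48.1%
- compound 2 `CCCc1nc(-c2ccccc2)c(CNCCCN2CCN(c3ccccc3C(F)(F)F)CC2)o1`: 45%
- compound 3 `CCCc1nc(-c2ccccc2)c(CNCCN2CCN(c3ccccc3C(F)(F)F)CC2)o1`: 54.6%

In an assay on HEK293 cells for inhibition of Voltage-dependent T-type calcium channel subunit alpha-1G (Homo sapiens), read by fluorescence, tested at 10 uM (on this read-out lower numbers stand for less inhibition and higher numbers for more inhibition at the one concentration tested (going by the name of the read-out)), compound 2 gives 45%, the lowest of the three numbers, yet its gaps to compound 1 and to compound 3 both lie within the scatter, so no order among the three can be claimed.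

Compound 4 `CCCc1nc(-c2ccccc2)c(CNCCCN2CCN(c3ccccc3C)CC2)o1` has not been measured. It differs from compound 2 by methyl in place of trifluoromethyl on an aromatic carbon.

Among the measured compounds shown here, only one measured step touches the aryl substituent: a number 6.5 percentage points higher from compound 1 to compound 3 (within the scatter). That step exchanges both the group and its place on the ring at once, so it bears on the present change only loosely; what it shows is that the difference between a methyl-bearing and a trifluoromethyl-bearing aryl piece stayed within the scatter. The same aryl group as in compound 2 sits on a different linker in compound 3, which gives 54.6%, again within the scatter of the number of compound 2.

No step beyond the scatter is therefore expected for a number 1 percentage points higher from compound 2 to compound 4 (within the scatter). Compound 4 is estimated at 46%, with a range of 32% to 60%.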

Compound 4, a percentage reported as inhibition, at one concentration (the size of the read-out at that concentration, not a potency): 54.5%
Compound 4: middle estimate off by 8.5 percentage points, on the low side, and the stated range covers the measured number.
By their numbers in this assay, from the lowest: compounds 2, 1, 4 and 3 (each within the scatter of the next).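

Earlier compounds changed the aryl group and its place together, whereas here 2-(trifluoromethyl)phenyl gives way to 2-methylphenyl with the place and the chain of compound 2 held fixed. In this assay, among the compounds shown here, this single change reads as (a number 9.5 percentage points higher from compound 2 to compound 4 (within the scatter)), the first reading of methyl against trifluoromethyl alone at this position. Within the scatter, the read-out does not separate the two groups here, and nothing measured bears on the size of this step.

Open, on these data alone, is whether other groups on this aromatic carbon, such as a chlorine atom, a methoxy group or an amine, would read apart from methyl and trifluoromethyl. Also open is how 2-methylphenyl reads on the chain of compound 3, and how any of these compounds compare in potency, which one concentration cannot show.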